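Removing Three Methoxy Groups From Compound 2

The source may hold more compounds than are shown below. What is called first, only, known or untested is meant among the compounds shown, and "the series" means these compounds.

Two compounds have been measured in a functional assay on NCI-H460 cells (Homo sapiens) for cytotoxicity, read by MTT assay, with a stated time of 72 h; on this read-out lower numbers stand for stronger inhibition and higher numbers for weaker inhibition:
compound 1 `COc1ccc(/C=N/NC(=O)Nc2ccc(Oc3ccnc(-c4nncn4CCN(C)C)c3)c(F)c2)c(OC)c1` gives 1570 nM;
compound 2 `COc1ccc(/C=N/NC(=O)Nc2ccc(Oc3ccnc(-c4nncn4CCN(C)C)c3)c(F)c2)c(OC)c1OC` gives 1790 nM.

Compound 2 and compound 1 sit within the scatter of each other in this assay, since a 1.1-fold higher number from compound 1 to compound 2 (0.06 log units; within the scatter); the two cannot be told apart on these numbers.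

Compound 3 `CN(C)CCn1cnnc1-c1cc(Oc2ccc(NC(=O)N/N=C/c3ccccc3)cc2F)ccn1` is the next candidate. The change from compound 2 is phenyl in place of 2,3,4-trimethoxyphenyl on a carbon with a double bond to nitrogen. For the measured compounds named here, only one measured step bears on it: a 1.1-fold higher number from compound 1 to compound 2 (0.06 log units; within the scatter), which covers one methoxy group added to that same ring and made no difference beyond the scatter. Going by the values given here, the present change goes further, taking away all three methoxy groups at once, and no measured pair shows what that does. Among the compounds with values here, with the one related step being flat, the expectation is that compound 3 will land close to compound 2, with an estimated step of a 1.2-fold lower number from compound 2 to compound 3 (0.08 log units; within the scatter) in this assay, and any direction is uncertain. The estimate for compound 3 in this assay is therefore 1500 nM, within a range from 500 nM to 4500 nM.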

Compound 3, half-maximal inhibitory concentration: 1780 nM
Estimate against measurement, compound 3: 1.2-fold (0.07 log units) below, within the range that was stated.
By their numbers in this assay, from the lowest: compounds 1, 3 and 2 (each within the scatter of the next).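

In this assay, taking away all three methoxy groups, so that a phenyl replaces a 2,3,4-trimethoxyphenyl, gives a 1.0-fold lower number from compound 2 to compound 3 (0.00 log units; within the scatter). Set against the 2,4-dimethoxyphenyl, the same bare phenyl gives a 1.1-fold higher number from compound 1 to compound 3 (0.05 log units; within the scatter), so the earlier flat step for a single methoxy group now extends to the complete removal of these groups, and the three compounds cannot be told apart by their numbers. Nothing available explains why this part of the molecule can change so much with no readable difference in this cell test.

On these data alone, all three compounds carry either a bare phenyl or a phenyl with methoxy groups on the carbon with a double bond to nitrogen, so it remains open whether a ring bearing an amine or a carboxylic acid would also stay within the scatter. As far as these compounds go, it is equally open whether this flat picture would hold on a different core or in a different kind of cell, since all of these numbers come from one shared core in one assay.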